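This account rests on a few compounds, and the source may have more. Where it says the series, first, only, none or still open, it means among the compounds named here.

Among the compounds with values here, compound 1 `CCCCCC(=O)OCC1CN(C(=O)c2cc(OC)c(OC)c(OC)c2)CCN1C(=O)c1cc(OC)c(OC)c(OC)c1` is one of two compounds measured in a functional assay (Oryctolagus cuniculus) for inhibition of platelet-activating factor receptor (Cavia porcellus); a higher number here means a weaker inhibitor, a lower number a stronger inhibitor; in this assay compound 1 gives 290 nM, the lowest of the two numbers. Within the data shown here, compound 2 `CCCCCCCCCCCCCCCCCC(=O)OCC1CN(C(=O)c2cc(OC)c(OC)c(OC)c2)CCN1C(=O)c1cc(OC)c(OC)c(OC)c1` carries a much longer chain and in this assay compound 2 gives 45000 nM, so that the step of a 160-fold higher number from compound 1 to compound 2 (2.19 log units; beyond the scatter) is the only measured comparison. Compound 3 `CCCCNC(=O)OCC1CN(C(=O)c2cc(OC)c(OC)c(OC)c2)CCN1C(=O)c1cc(OC)c(OC)c(OC)c1` differs from compound 1 in another way: butylamino in place of pentyl on a carbonyl carbon. Here the size of the chain is hardly altered, whereas the one measured step concerns a large gain in chain length, so it bears only indirectly on the change at hand; it shows that this assay can move strongly with the chain, but offers no direct reading of an ester replaced by a carbamate of like size. A step of at most modest size is therefore expected, a 1.6-fold higher number from compound 1 to compound 3 (0.19 log units; within the scatter), in either direction. Compound 3 is estimated at 450 nM, with a range from 120 nM to 1700 nM.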

Compound 3, half-maximal inhibitory concentration: 240 nM
Compound 3: middle estimate off by 1.9-fold (0.27 log units), on the high side; the range from low to high includes it.
By their numbers in this assay, from the lowest: compounds 3 and 1 (each within the scatter of the next); then compound 2.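

In this assay, butylamino in place of pentyl on a carbonyl carbon gives a 1.2-fold lower number from compound 1 to compound 3 (0.08 log units; within the scatter), so the ester of compound 1 and the carbamate of compound 3 cannot be told apart here, even though the change brings in a hydrogen-bond donor. Where the earlier comparison showed only that this side chain can matter greatly when it is lengthened, this result shows that a change of atom type within the chain, at a like size, leaves the number within the scatter. Nothing at hand explains this outcome.

Still open, going by these compounds, is whether a much longer chain on the carbamate nitrogen would behave as the longer ester chain did in a 160-fold higher number from compound 1 to compound 2 (2.19 log units; beyond the scatter). On these data alone, it is also open how an amide or an ether in place of the ester linkage would read in this assay.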